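The source may hold more compounds than are shown below. What is called first, only, known or untested is meant among the compounds shown, and "the series" means these compounds.

Measured so far:
compound 1, `COc1ccc(-c2nc(C)c(C(=O)CSc3nc(N)c(C#N)c(-c4ccc(Cl)cc4)n3)s2)cc1`: 3.9% in a functional assay on U-87MG ATCC cells for antiproliferative activity against U-87 MG (Homo sapiens), read by MTT assay, with a stated time of 48 h, tested at 100 uM; a lower number here means a stronger effect, a higher number a weaker effect of the compound at the concentration tested
compound 2, `COc1ccc(-c2nc(C)c(C(=O)CSc3nc(N)c(C#N)c(-c4ccccc4)n3)s2)cc1`: 5.25% in this assay

Among the measured compounds shown here, compound 2 and compound 1 sit within the scatter of each other in this assay; the only step recorded so far, a number 1.4 percentage points higher from compound 1 to compound 2 (within the scatter), is one of hydrogen in place of chloro on an aromatic carbon, and it did not move the read-out beyond the scatter. Both measured compounds therefore show a low read-out at the concentration tested, i.e. a strong effect.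

Compound 3, `Cc1nc(-c2ccccc2)sc1C(=O)CSc1nc(N)c(C#N)c(-c2ccccc2)n1`, differs from compound 2 as follows: hydrogen in place of methoxy on an aromatic carbon. For the measured compounds named here, no measured step touches the 4-methoxyphenyl group on the core, so the step to compound 3 has no direct precedent. The nearest comparison is the removal of a substituent from an aromatic ring elsewhere in the molecule, a number 1.4 percentage points higher from compound 1 to compound 2 (within the scatter), which stayed within the scatter. On that basis compound 3 is expected to stay close to compound 2 in this assay, with a step of a number 2.8 percentage points higher from compound 2 to compound 3 (within the scatter) that is expected to remain within or just at the edge of the scatter. The estimate for compound 3 is 8%, with a range from 2% to 22%.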

Compound 3, a percentage reported as activity, at one concentration (the size of the read-out at that concentration, not a potency): 6.48%
For compound 3 the middle estimate is 1.5 percentage points above the measured one, within the range that was stated.
By their numbers in this assay, from the lowest: compounds 1, 2 and 3 (each within the scatter of the next).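

In this assay, hydrogen in place of methoxy on the aromatic carbon para to a large group gives a number 1.2 percentage points higher from compound 2 to compound 3 (within the scatter), the first step recorded at the 4-methoxyphenyl group. The low read-out at the concentration tested therefore does not depend on methoxy at this place: compound 3, with a plain phenyl, keeps it. Together with a number 1.4 percentage points higher from compound 1 to compound 2 (within the scatter) on the other aromatic ring, this gives two single-place removals of a ring substituent, each within the scatter, though neither says how the two rings would behave with other groups, and nothing available explains the flat result at this position.

Since the read-out is a size at one concentration and not a potency, real differences in potency among these compounds could lie hidden under these low numbers, and a series of concentrations would be needed to show them. On these data alone, it also stays open whether this place tolerates groups unlike methoxy and hydrogen, such as an amine, a carboxylic acid or a longer chain like butoxy, or whether one of these would lift the read-out beyond the scatter.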